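Series notes: aryl group on the aromatic nitrogen

The source may report more compounds than this note shows. Statements on the series, on what has been measured and on what is new or still open speak of the compounds shown alone.

Measured compounds:
Compound 1 `COc1ccc(-n2cc(COc3cccc(NC(=O)Nc4ccc(Cl)c(C(F)(F)F)c4)c3)nn2)cc1` gives 4680 nM in a functional assay on HepG2 cells (Homo sapiens) for inhibition, read by MTT assay, with a stated time of 72 h; on this read-out higher numbers stand for weaker inhibition and lower numbers for stronger inhibition.
Compound 2 `O=C(Nc1cccc(OCc2cn(-c3ccc(F)cc3)nn2)c1)Nc1ccc(Cl)c(C(F)(F)F)c1` gives 1350 nM in this assay.
Compound 3 `O=C(Nc1cccc(OCc2cn(-c3ccccc3Cl)nn2)c1)Nc1ccc(Cl)c(C(F)(F)F)c1` gives 1960 nM in this assay.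

Compound 3 stands second highest of the three numbers. Its nearest neighbour is compound 2, and the step from compound 2 to compound 3 is a 1.5-fold higher number from compound 2 to compound 3 (0.16 log units; within the scatter). Its furthest neighbour is compound 1, with a 2.4-fold lower number from compound 1 to compound 3 (0.38 log units; beyond the scatter). The remaining step, a 3.5-fold lower number from compound 1 to compound 2 (0.54 log units; beyond the scatter), is of the same modest size.

Compound 4 `O=C(Nc1cccc(OCc2cn(-c3ccccc3C(F)(F)F)nn2)c1)Nc1ccc(Cl)c(C(F)(F)F)c1` differs from compound 3 by trifluoromethyl in place of chloro on an aromatic carbon. For the measured compounds named here, no measured step covers this change at that place; the two steps that touch the aryl group on the aromatic nitrogen, a 2.4-fold lower number from compound 1 to compound 3 (0.38 log units; beyond the scatter) and a 1.5-fold higher number from compound 2 to compound 3 (0.16 log units; within the scatter), were modest or within the scatter. A step of that order is therefore expected for a 1.0-fold higher number from compound 3 to compound 4 (0.01 log units; within the scatter), with no direction that the data support. Compound 4 is estimated at 2000 nM, within 900 nM to 4500 nM in this assay.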

Compound 4, half-maximal inhibitory concentration: 2320 nM
Compound 4: the middle estimate sits 1.2-fold (0.06 log units) below what was measured; the measured number falls inside the stated range.
By their numbers in this assay, from the lowest: compounds 2, 3, 4 and 1 (each within the scatter of the next, the first and the last beyond it).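

In this assay, for the compounds shown here, the first reading of trifluoromethyl in place of chloro on an aromatic carbon, ortho to a large group, gives no separation between the two groups (a 1.2-fold higher number from compound 3 to compound 4 (0.07 log units; within the scatter)). Going by these compounds alone, the 2-(trifluoromethyl)phenyl group also stays within the scatter of both other aryl groups (a 1.7-fold higher number from compound 2 to compound 4 (0.24 log units; within the scatter); a 2.0-fold lower number from compound 1 to compound 4 (0.30 log units; within the scatter)), whereas compound 2 and compound 3 each lie beyond the scatter of compound 1, so compound 4 is the first 2-substituted member that cannot be separated from compound 1. No measurement at hand speaks to the cause of these numbers.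

The compounds shown leave open how an aryl group carrying an amine or a carboxylic acid, or a benzyl group on the aromatic nitrogen, would read in this assay. Trifluoromethyl and chloro are compared at one place only, so whether the same change reads alike elsewhere on that ring also remains open.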